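The source may hold more compounds than are shown below. What is called first, only, known or untested is meant among the compounds shown, and "the series" means these compounds.

Measured so far in an assay on cells for displacement of a labelled ligand from adenosine receptor A1 (Homo sapiens), read by scintillation counting, with a stated time of 120 min, tested at 1 uM; on this read-out higher numbers stand for more inhibition at the one concentration tested (going by the name of the read-out) and lower numbers for less inhibition:

compound 1 `Cc1ccc(C(=O)Nc2nc(-c3ccccc3)cn3cc(-c4ccccc4)nc23)cc1` gives 1%
compound 2 `O=C(Nc1nc(-c2ccccc2)cn2cc(-c3ccccc3)nc12)c1ccc(Cl)cc1` gives 1%
compound 3 `O=C(Nc1nc(-c2ccccc2)cn2cc(-c3ccccc3)nc12)c1ccc(F)cc1` gives 1%

All three compounds share one core and differ only in the group carried on one aromatic carbon of the benzamide ring. On the numbers, compound 3 stands level with compounds 1 and 2: the step of no change at the digits printed from compound 1 to compound 3 (within the scatter) and the step of no change at the digits printed from compound 2 to compound 3 (within the scatter) are both flat, as is the step of no change at the digits printed from compound 1 to compound 2 (within the scatter). Among the measured compounds shown here, in other words, swapping methyl, chloro and fluoro at that aromatic carbon made no difference that can be told from repeat scatter, and every compound so far sits at the bottom of the scale in this assay.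

Compound 4 `O=C(c1ccc(F)cc1)N(C(=O)c1ccc(F)cc1)c1nc(-c2ccccc2)cn2cc(-c3ccccc3)nc12` is the next step. Its change from compound 3 is (4-fluorophenyl)carbonyl in place of hydrogen on an amide-type nitrogen, so the amide hydrogen is replaced by a second (4-fluorophenyl)carbonyl group. For the measured compounds named here, none of the measured steps touches this amide nitrogen; they all concern a substituent on an aromatic carbon, and all were within the scatter. They therefore give no direction for this change, only the observation that every variation tried so far left the inhibition near zero. Going by the values given here, with that as the only guide, compound 4 is expected to show the same low level, with the step of a number 1 percentage points higher from compound 3 to compound 4 (within the scatter) expected to be nothing beyond the scatter. The estimate for compound 4 is 2%, with a range from 0% to 15%.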

Compound 4, a percentage reported as inhibition, at one concentration (the size of the read-out at that concentration, not a potency): 1%
Compound 4: middle estimate off by 1 percentage points, on the high side; low and high end bracket the measured number.
By their numbers in this assay, from the lowest: compounds 1, 2, 3 and 4 (each within the scatter of the next).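

In this assay the change from the amide hydrogen to a (4-fluorophenyl)carbonyl group gives no change at the digits printed from compound 3 to compound 4 (within the scatter) and is the first step shown at the amide-type nitrogen, not on an aromatic carbon. Although this change adds 9 heavy atoms and a six-membered aromatic ring, the flat picture seen on the benzamide ring extends to this second position, and losing the amide hydrogen brings no gain in inhibition that can be told from the scatter. Any further loss would be hard to see, as these compounds already sit at the bottom of the scale, and no supporting measurement is available to explain the result.

The compounds shown leave open whether any group at either position can raise the inhibition off the bottom of the scale, such as a small methyl on the amide-type nitrogen, or an amine or a carboxylic acid on the benzamide ring. With only one concentration tested, they also leave open whether these compounds would displace the labelled ligand at higher concentrations.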